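The source may report more compounds than this note shows. Statements on the series, on what has been measured and on what is new or still open speak of the compounds shown alone.

In a functional assay on A549 cells (Homo sapiens) for antiproliferative activity, read by MTT assay, with a stated time of 72 h (on this read-out higher numbers stand for weaker inhibition and lower numbers for stronger inhibition), compound 1 (`COc1cc(-n2cnc3ccc(-c4ccc([N+](=O)[O-])cc4)cc32)cc(OC)c1OC`) gives 8940 nM while compound 2 (`COc1cc(-n2cnc3ccc(-c4ccc(C(F)(F)F)cc4)cc32)cc(OC)c1OC`) gives 3390 nM and compound 3 (`COc1cc(-n2cnc3ccc(-c4cccc([N+](=O)[O-])c4)cc32)cc(OC)c1OC`) gives (5410 nM). Compound 3 thus lies inside the span of the other two and within the scatter of each. Compound 4 (`COc1cc(-n2cnc3ccc(-c4ccc(Cl)cc4)cc32)cc(OC)c1OC`) has 4-chlorophenyl in place of 3-nitrophenyl on an aromatic carbon. Going by the values given here, no measured step involves 4-chlorophenyl, so the guides are indirect. Trifluoromethyl in place of nitro gave a 2.6-fold lower number from compound 1 to compound 2 (0.42 log units; beyond the scatter) while 3-nitrophenyl in place of 4-nitrophenyl gave a 1.7-fold lower number from compound 1 to compound 3 (0.22 log units; within the scatter) and 3-nitrophenyl in place of 4-(trifluoromethyl)phenyl gave (a 1.6-fold higher number from compound 2 to compound 3 (0.20 log units; within the scatter)). All three steps are small, so only a small shift toward a lower number is expected in this assay and none beyond the scatter. The expected change is a 1.4-fold lower number from compound 3 to compound 4 (0.13 log units; within the scatter) in this estimate. Compound 4 is estimated at 4000 nM with 1900 nM to 8500 nM as its expected range.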

Compound 4, half-maximal inhibitory concentration: > 10000 nM
Compound 4: only a limit was reported (the forecaster's own chance of this, stated with the estimate: 2%); middle value at least 2.5-fold (0.39 log units) away from the limit.
By their numbers in this assay, from the lowest: compounds 2, 3 and 1 (each within the scatter of the next, the first and the last beyond it). At a limit, above all of these: compound 4.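

In this assay compound 4 gives only a limit, not a number: the limit of > 10000 nM in this assay, at which 1 of the 4 values shown sits. The step of an at least 2.9-fold higher number from compound 2 to compound 4 (0.46 log units; beyond the scatter) shows that, at this position, chloro in place of trifluoromethyl moves the number beyond the scatter, the first such rise among these compounds. The steps of an at least 1.8-fold higher number from compound 3 to compound 4 (0.26 log units; that floor lies within the scatter) and an at least 1.1-fold higher number from compound 1 to compound 4 (0.04 log units; that floor lies within the scatter) have floors within the scatter, so they alone fix no order.

On these data alone, the actual number for compound 4 remains unknown. The compounds shown also leave open how an amine or a carboxylic acid on this phenyl ring would read.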